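The compounds below may be only part of what the source reports. "The series", "measured", "known", "first", "only" and "open" are said of these compounds alone.

Three compounds were measured in a functional assay on MCF7 cells (Homo sapiens) for inhibition, read by MTT assay, with a stated time of 72 h; a higher number here means a weaker inhibitor, a lower number a stronger inhibitor:

`O=C(OC1(C(=O)Nc2ccc([N+](=O)[O-])cc2)CCCCC1)c1ccc(C(F)(F)F)cc1` compound 1: 27.1 nM
`CCOC(=O)c1ccccc1C(=O)OC1(C(=O)Nc2ccc([N+](=O)[O-])cc2)CCCCC1` compound 2: 444 nM
`O=C(/C=C/c1ccccc1)OC1(C(=O)Nc2ccc([N+](=O)[O-])cc2)CCCCC1` compound 3: 57.6 nM

Compound 3 holds the second highest number of the three. Its nearest neighbour is compound 1, separated by the step of a 2.1-fold higher number from compound 1 to compound 3 (0.33 log units; beyond the scatter), while compound 2 sits far higher. Compound 4 `O=C(OC1(C(=O)Nc2ccc([N+](=O)[O-])cc2)CCCCC1)c1ccccc1` differs from compound 3 by phenyl in place of 2-phenylethenyl on a carbonyl carbon. Going by the values given here, the only measured step at this carbonyl carbon is a 2.1-fold higher number from compound 1 to compound 3 (0.33 log units; beyond the scatter), a modest change for swapping one group for another there; the high number of compound 2 shows that a different group at the same place can cost much more. A phenyl group is expected to behave more like the groups of compound 1 and compound 3 than that of compound 2, so the estimated step is a 1.3-fold lower number from compound 3 to compound 4 (0.11 log units; within the scatter), small and toward a lower number. Compound 4 is estimated at 45 nM, within 15 nM to 140 nM.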

Compound 4, half-maximal inhibitory concentration: 903 nM
Beside the measured number, compound 4's estimate is 20-fold (1.30 log units) below it; the measured number lies above the stated range.
By their numbers in this assay, from the lowest: compound 1; then compound 3; then compound 2; then compound 4.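

Plain phenyl at this carbonyl carbon makes compound 4 the weakest of the four in this assay, so replacing 2-phenylethenyl with phenyl is far from neutral (a step of a 16-fold higher number from compound 3 to compound 4 (1.20 log units; beyond the scatter)). All three other groups at this carbon give lower numbers, but by very different amounts: trifluoromethyl on the ring accounts for a large step (hydrogen in its place gives a 33-fold higher number from compound 1 to compound 4 (1.52 log units; beyond the scatter)), ethoxycarbonyl for a modest one (hydrogen in its place gives a 2.0-fold higher number from compound 2 to compound 4 (0.31 log units; beyond the scatter)). Nothing available explains these differences.

Going by these compounds, whether the double bond matters remains open, and a saturated 2-phenylethyl group would test it. Also open, on these data alone, is whether a chlorine or a methoxy group on the ring would match trifluoromethyl.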